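The source may report more compounds than this note shows. Statements on the series, on what has been measured and on what is new or still open speak of the compounds shown alone.

Of the compounds shown here, three have so far been measured in a functional assay on HepG2 cells (Homo sapiens) for cytotoxicity, read by MTT assay, with a stated time of 72 h; a higher number here means a weaker inhibitor, a lower number a stronger inhibitor. Compound 1 `COc1ccc2ccc(=O)oc2c1C(/C=C/c1ccc(C(F)(F)F)cc1)=N/NC(N)=O` gives 96 nM there. Compound 2 `COc1ccc2ccc(=O)oc2c1C(/C=C/c1ccc(SC)cc1)=N/NC(N)=O` differs from compound 1 in one place, (methylsulfanyl in place of trifluoromethyl on an aromatic carbon). In this assay compound 2 gives 99 nM, so the step from one to the other is a 1.0-fold higher number from compound 1 to compound 2 (0.01 log units; within the scatter). Compound 3 `COc1ccc2ccc(=O)oc2c1C1=NN(C(C)=O)C(c2ccc(C(F)(F)F)cc2)C1` carries a different core from compound 1; the difference between the two cores is not broken down here. In this assay compound 3 gives 80 nM, a number within the scatter of both compound 1 and compound 2.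

Compound 4 `COc1ccc2ccc(=O)oc2c1C1=NN(C(C)=O)C(c2ccc(SC)cc2)C1` has not yet been measured. It differs from compound 3 by methylsulfanyl in place of trifluoromethyl on an aromatic carbon. The place described is the same word for word as in the change from compound 1 to compound 2, so this is the same change, made now on the core of compound 3. The step expected from this change is a 1.1-fold higher number from compound 3 to compound 4 (0.03 log units; within the scatter), resting on the earlier step of a 1.0-fold higher number from compound 1 to compound 2 (0.01 log units; within the scatter). In this assay compound 4 is therefore estimated to give 85 nM, most likely between 45 nM and 160 nM.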

Compound 4, half-maximal inhibitory concentration: 42 nM
Estimate against measurement, compound 4: 2.0-fold (0.31 log units) above, and the stated range ends above it.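

In this assay the placing of methylsulfanyl where trifluoromethyl stood on the second core gives a 1.9-fold lower number from compound 3 to compound 4 (0.28 log units; within the scatter) and so stays within the usual scatter of repeated measurements. Set beside the same change on the first core, this step cannot be told apart from the earlier one: the same change on two cores in this assay, a 1.0-fold higher number (0.01 log units; within the scatter) from compound 1 to compound 2 and a 1.9-fold lower number (0.28 log units; within the scatter) from compound 3 to compound 4, 2.0-fold (0.29 log units) apart, within the scatter of two such steps. On these two cores, then, the change behaves alike as far as this assay can tell, with neither step standing clear of the scatter, but two pairs of compounds cannot show that it would carry over to any further core, and they cannot reveal a real difference smaller than the scatter.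

Among these compounds, only two groups appear at this place on the ring, so it remains open how an amine, a carboxylic acid or a longer chain there would read on either core. From the compounds shown here alone, it also remains open whether this change would look the same in any assay other than this one.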